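Chloropyridyl ether series: moving the chlorine

This account rests on a few compounds, and the source may have more. Where it says the series, first, only, none or still open, it means among the compounds named here.

Among the compounds with values here, compound 2 `Cn1c(COc2cccc(C(=O)O)c2)nc2ccc(Oc3cccc(Cl)n3)cc21` carries the higher of the two numbers so far in a physicochemical assay for lipophilicity, read by LC-MS, in phosphate buffer, measured as octanol-water partition, with a stated time of 30 min, at pH 7.4, tested at 200 mM (a lower number here means a more polar compound, a higher number a more lipophilic compound), where compound 2 gives 1.2. Compound 1 `Cc1ccc(Oc2cc3c(cn2)nc(COc2cccc(C(=O)O)c2)n3C)cc1` gives 1 in this assay, a value within the scatter of that of compound 2, so no order between them is claimed. Compound 3 `Cn1c(COc2cccc(C(=O)O)c2)nc2ccc(Oc3ncccc3Cl)cc21` differs from compound 2 by 3-chloropyridin-2-yl in place of 6-chloropyridin-2-yl on an oxygen on an aromatic ring. Within the data shown here, no measured pair shows this change. In this assay the expected step is a number 0.10 log units lower from compound 2 to compound 3 (within the scatter), none beyond the scatter. For compound 3 the estimate is 1.1, with a range from 0.7 to 1.5.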

Compound 3, distribution coefficient: 1.1
Estimate against measurement, compound 3: no gap at the digits printed; the range from low to high includes it.
By their numbers in this assay, from the lowest: compounds 1, 3 and 2 (each within the scatter of the next).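

Moving the chlorine gives the first pair in the series that differs in one place, on an oxygen on an aromatic ring. In this assay the change from 6-chloropyridin-2-yl to 3-chloropyridin-2-yl reads as a number 0.10 log units lower from compound 2 to compound 3 (within the scatter), so this move of the chlorine does not separate the two compounds. No measurement at hand bears on the reason for this result. On these data alone, whether an amine or a methoxy group in place of the chlorine would give a step beyond the scatter in this assay remains open.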